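A few compounds are considered here, and "the series" means these few. Any claim that something is new, unique, unknown or untested is made for them only; others in the source may bear on it.

Series notes. Compound 1 `CC(=O)c1sc(/N=C2\NC(=O)/C(=C3/C(=O)N(C)c4ccccc43)S2)nc1C` and compound 2 `CCOC(=O)c1sc(/N=C2\NC(=O)/C(=C3/C(=O)N(C)c4ccccc43)S2)nc1C` share one core. In an ADME assay on RAW264.7 cells (Mus musculus) for cytotoxicity (a higher number here means a weaker inhibitor of growth, a lower number a stronger inhibitor of growth), compound 1 gives only a limit of > 250 ug/mL and no number. In this assay compound 2 gives 500 ug/mL and is the sole numerical point in the set. The step that the limit leaves unreadable from compound 1 to compound 2 stays unreadable because the limit of > 250 ug/mL in this assay, at which 1 of the 2 values shown sits, covers compound 1. Among the measured compounds shown here, compound 3 `CCOC(=O)c1sc(/N=C2\NC(=O)/C(=C3/C(=O)N(Cc4ccccc4)c4ccccc43)S2)nc1C` differs from compound 2 by phenyl in place of hydrogen on a saturated chain carbon bound to an amide-type nitrogen in a ring and has no measured counterpart in the set. A moderate drop in this assay is estimated, as the step of a 2.0-fold lower number from compound 2 to compound 3 (0.30 log units; within the scatter) shows. Compound 3 is expected at 250 ug/mL (range 80 ug/mL to 600 ug/mL in this assay).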

Compound 3, concentration for 50% growth inhibition: 500 ug/mL
Estimate against measurement, compound 3: 2.0-fold (0.30 log units) below; the range from low to high includes it.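

Phenyl in place of hydrogen on a saturated chain carbon bound to an amide-type nitrogen in a ring gives, in this assay, no change at the digits printed from compound 2 to compound 3 (within the scatter). Among the compounds shown here, this is the first readable step, and it shows that methyl to benzyl at this position leaves the read-out unchanged when ethoxy sits on the carbonyl carbon. Nothing shown bears on the reason for this result.

Still open, going by these compounds, is how a longer alkyl chain or an amine would read at this position. Also open, on these data alone, is whether methyl to benzyl reads the same with methyl on the carbonyl carbon, as in compound 1.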